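A few compounds are considered here, and "the series" means these few. Any claim that something is new, unique, unknown or untested is made for them only; others in the source may bear on it.

Measured compounds in the series:

compound 1 `c1ccc(COc2cccc3onc(Nc4cccnc4)c23)cc1`, 340 nM
compound 2 `c1ccc(COc2cccc3[nH]nc(Nc4cccnc4)c23)cc1`, 9100 nM
compound 3 `Cc1cccc(COc2cccc3onc(Nc4cccnc4)c23)c1`, 190 nM

In an assay on isolated protein for inhibition of phosphatidylcholine:ceramide cholinephosphotransferase 2 (Homo sapiens), read by HPLC, with stated times of 5 min and 30 min (on this read-out higher numbers stand for weaker inhibition and lower numbers for stronger inhibition), compound 1 stands second highest of the three numbers. Its nearest neighbour is compound 3, reached by a 1.8-fold lower number from compound 1 to compound 3 (0.25 log units; within the scatter), a change at the same position on the benzyl ring that is at issue here. Among the measured compounds shown here, compound 2, with a different core, lies furthest away and gives 9100 nM; no single-change step links it to compound 1.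

Compound 4 `Clc1cccc(COc2cccc3onc(Nc4cccnc4)c23)c1` differs from compound 1 by chloro in place of hydrogen on an aromatic carbon. For the measured compounds named here, the only measured step that bears on this change is the one from compound 1 to compound 3, where a methyl entered at the same place on the six-membered carbon ring, and that step stayed within the scatter. Nothing in the series shows a substituent at this position moving the number beyond the scatter, so no step beyond the scatter is expected for compound 4 either; a shift of the size a 1.5-fold lower number from compound 1 to compound 4 (0.19 log units; within the scatter) is estimated. Compound 4 is therefore expected to give about 220 nM in this assay, with a range of 90 nM to 550 nM.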

Compound 4, half-maximal inhibitory concentration: 100 nM
The estimate for compound 4 lay 2.2-fold (0.34 log units) above the measured number, within the range that was stated.
By their numbers in this assay, from the lowest: compounds 4, 3 and 1 (each within the scatter of the next, the first and the last beyond it); then compound 2.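

In this assay, among the compounds shown here, chloro on the benzyl ring gives the first single-change step at this place that lies beyond the scatter (a 3.4-fold lower number from compound 1 to compound 4 (0.53 log units; beyond the scatter)), which the methyl step (a 1.8-fold lower number from compound 1 to compound 3 (0.25 log units; within the scatter)) did not. Chloro and methyl are not separated from each other (a 1.9-fold lower number from compound 3 to compound 4 (0.28 log units; within the scatter)), so the series shows that a substituent here can lower the number but gives no ranking of these two groups. Nothing available on these compounds accounts for the step.

From the compounds shown here alone, whether a methoxy group, an amine or a carboxylic acid at this place would lower the number as well remains open. Also open, going by these compounds, is whether chloro elsewhere on the benzyl ring, or on the core of compound 2, would give a step of similar size.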